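Working notes: hydroxy in place of tert-butyl

The source may report more compounds than this note shows. Statements on the series, on what has been measured and on what is new or still open speak of the compounds shown alone.

Measured in a toxicity assay on Vero C1008 cells (Chlorocebus sabaeus) for cytotoxicity, read by MTT assay, with a stated time of 48 h; on this read-out higher numbers stand for lower toxicity in this test and lower numbers for higher toxicity in this test:
- compound 1 `O=C(Nc1cccc([N+](=O)[O-])c1)c1cc(Cl)ccc1O` gives 3530 nM
- compound 2 `CC(C)(C)c1cccc(NC(=O)c2cc(Cl)ccc2O)c1` gives 2360 nM

Compound 2 has only compound 1 for comparison in this assay, and the two values are not separated by more than the scatter. The next structure is compound 3 `O=C(Nc1cccc(O)c1)c1cc(Cl)ccc1O`, not yet measured. Its change from compound 2 is hydroxy in place of tert-butyl on an aromatic carbon. Among the compounds with values here, the one measured step, a 1.5-fold lower number from compound 1 to compound 2 (0.17 log units; within the scatter), also exchanges the group at this place. Within the data shown here, it is the only guide, and no measured compound carries hydroxy there. With that step inside the scatter, no step beyond the scatter is expected in this assay, in either direction. For compound 3 the expected value is 3000 nM, with an estimated range of 1200 nM to 7000 nM. The expected step is a 1.3-fold higher number from compound 2 to compound 3 (0.10 log units; within the scatter).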

Compound 3, half-maximal cytotoxic concentration: > 100000 nM
Compound 3: a limit, no number; the forecaster's own chance of this, stated with the estimate: 5%; middle value at least 33-fold (1.52 log units) from the limit.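

In this assay compound 3 stands at a limit and not at a number: the limit of > 100000 nM in this assay, at which 1 of the 3 values shown sits. Tert-butyl and nitro, the two groups seen earlier on this aromatic carbon, gave values within the scatter of each other and so showed no dependence on the group here, whereas hydroxy in place of tert-butyl gives an at least 42-fold higher number from compound 2 to compound 3 (1.62 log units; beyond the scatter) and hydroxy in place of nitro gives an at least 28-fold higher number from compound 1 to compound 3 (1.45 log units; beyond the scatter). On the shared core, this place meta to a large group can therefore carry a large change towards lower toxicity in this test, a change seen so far with hydroxy alone.

From the compounds shown here alone, whether an amine or a carboxylic acid at this place would behave like hydroxy stays open. Going by these compounds, with compound 3 at a limit, the full size of both steps also stays open.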